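Benzylidene-piperazinedione series: variation at the meta-substituted aryl arm

A few compounds are considered here, and "the series" means these few. Any claim that something is new, unique, unknown or untested is made for them only; others in the source may bear on it.

Measured so far:
compound 1, `C=CCn1c(=O)/c(=C\c2cccc(C)c2)[nH]c(=O)/c1=C\c1ccccc1OC`, 20700 nM
compound 2, `C=CCn1c(=O)/c(=C\c2ccc(Cl)c(Cl)c2)[nH]c(=O)/c1=C\c1ccccc1`, "not active" (no number reported)
compound 3, `COc1ccccc1/C=c1\c(=O)[nH]/c(=C/c2ccccc2Cl)c(=O)n1C`, 200 nM

In a functional assay on MCF7 cells (Homo sapiens) for cytotoxicity, read by CCK-8 assay, with a stated time of 72 h (a higher number here means a weaker inhibitor, a lower number a stronger inhibitor), compound 1 gives 20700 nM, the highest of the two numbers in hand. Among the measured compounds shown here, the nearest measured number belongs to compound 3, which gives 200 nM, a gap beyond the scatter; compound 3 differs from compound 1 at more than one place, so no single step is assigned to that pair. Compound 2 is reported without a number in this assay.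

The next compound, compound 4 `C=CCn1c(=O)/c(=C\c2ccc(F)c(Br)c2)[nH]c(=O)/c1=C\c1ccccc1OC`, differs from compound 1 in one place: 3-bromo-4-fluorophenyl in place of 3-methylphenyl on a double-bonded chain carbon bound to an aromatic carbon. For the measured compounds named here, no pair of measured compounds isolates this exchange. Compound 2, which carries two halogens on the same arm, is the only other halogenated entry and has no number, which gives little to build on. The step from compound 1 to compound 4 is expected to be small and, if anything, toward a higher number, a 1.4-fold higher number from compound 1 to compound 4 (0.13 log units; within the scatter). For compound 4 the estimate in this assay is 28000 nM, with a range from 8000 nM to 90000 nM.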

Compound 4, half-maximal inhibitory concentration: "not active" (no number reported)
Compound 4 has no reported number here; the estimate stays without a comparison.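

In this assay, among the compounds shown here, compound 4 is reported as not active, without a number, so no step from compound 1 can be read. No supporting data bear on this result. The compounds shown leave open how far the 3-bromo-4-fluorophenyl exchange shifts the value relative to 3-methylphenyl.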